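Trading fluoro for trifluoromethyl on an aromatic carbon

This account rests on a few compounds, and the source may have more. Where it says the series, first, only, none or still open, it means among the compounds named here.

In an ADME assay on L02 cells (Homo sapiens) for cytotoxicity, read by MTT assay, with a stated time of 24 h (on this read-out lower numbers stand for stronger inhibition and higher numbers for weaker inhibition), compound 1 (`CN1C/C(=C\c2cccnc2)C(=O)/C(=C/c2ccccc2C(F)(F)F)C1`) gives 14100 nM and compound 2 (`O=C1/C(=C/c2cccnc2)CNC/C1=C\c1ccccc1F`) gives 15900 nM, so compound 2 stands within the scatter of compound 1. Compound 3 (`O=C1/C(=C/c2cccnc2)CNC/C1=C\c1ccccc1C(F)(F)F`) differs from compound 2 by trifluoromethyl in place of fluoro on an aromatic carbon. Within the data shown here, no measured pair isolates this exchange. Compound 1, which also carries trifluoromethyl, gives 14100 nM, so no change beyond the scatter is expected in this assay. The estimated step is a 1.2-fold lower number from compound 2 to compound 3 (0.09 log units; within the scatter). For compound 3 the expected value is 13000 nM, within an estimated range of 6000 nM to 28000 nM.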

Compound 3, half-maximal inhibitory concentration: 11300 nM
The estimate for compound 3 lay 1.2-fold (0.06 log units) above the measured number; low and high end bracket the measured number.
By their numbers in this assay, from the lowest: compounds 3, 1 and 2 (each within the scatter of the next).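

In this assay, the exchange of fluoro for trifluoromethyl on this aromatic carbon now has a measured pair, which gives a 1.4-fold lower number from compound 2 to compound 3 (0.15 log units; within the scatter) and so does not tell the two groups apart. Hydrogen in place of methyl on the amine nitrogen in the ring gives a 1.2-fold lower number from compound 1 to compound 3 (0.10 log units; within the scatter) and likewise does not separate those two compounds. Nothing measured here offers a reason for either step. From the compounds shown here alone, whether an amine or a carboxylic acid on this aromatic carbon would give a number beyond the scatter stays open. So does the effect of a longer chain on the ring nitrogen.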